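Nitro to amino on the benzylic sulfone series

A few compounds are considered here, and "the series" means these few. Any claim that something is new, unique, unknown or untested is made for them only; others in the source may bear on it.

Compound 1 `COc1ccc(CS(=O)(=O)/C=C/c2c(OC)cccc2OC)cc1[N+](=O)[O-]` and compound 2 `COc1ccc(CS(=O)(=O)/C=C/c2ccc(OC)c(OC)c2OC)cc1[N+](=O)[O-]` share the benzylic sulfone core and differ only in the methoxy pattern of the styryl ring. In a functional assay on T47D cells (Homo sapiens) for cytotoxicity, read by MTT assay, with a stated time of 72 h (a higher number here means a weaker inhibitor of growth, a lower number a stronger inhibitor of growth), compound 1 gives > 30000 nM, a limit of the assay and not a number. In this assay compound 2 likewise gives > 30000 nM, again a limit and not a number. Compound 2 therefore stands at the limit of > 30000 nM in this assay, at which 2 of the 2 values shown sit, with nothing in the measured set lying below it. Compound 3 `COc1ccc(CS(=O)(=O)/C=C/c2ccc(OC)c(OC)c2OC)cc1N` is yet to be measured in this assay; it differs from compound 2 by amino in place of nitro on an aromatic carbon. Among the compounds with values here, no measured step of this kind exists, so no direction beyond the scatter is expected, and the step from compound 2 to compound 3 in this assay is expected to be a step that the limit leaves unreadable from compound 2 to compound 3. Compound 3 is estimated at 40000 nM, within 10000 nM to 150000 nM, most likely reported again only as a limit.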

Compound 3, concentration for 50% growth inhibition: 5900 nM
Beside the measured number, compound 3's estimate is 6.8-fold (0.83 log units) above it; the measured number lies below the stated range.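

In this assay, amino in place of nitro on an aromatic carbon, ortho to a methoxy group, gives an at least 5.0-fold lower number from compound 2 to compound 3 (0.70 log units; beyond the scatter), with the rest of the structure unchanged. This is the first change in the series shown to bring a value off the limit, so this position can move growth inhibition, whereas the two nitro compounds could not be told apart. Compound 2 stands at a limit and not a number, so the step fixes only a minimum size because its starting point is open: the limit of > 30000 nM in this assay, at which 2 of the 3 values shown sit.

The compounds shown leave open whether amino has the same effect on the methoxy pattern of compound 1. They also leave open whether a free amine is needed here, or whether an acetamide, a dimethylamino group or a hydroxyl at this position would serve as well.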